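Series notes: from compound 3 to compound 4

The source may hold more compounds than are shown below. What is called first, only, known or untested is meant among the compounds shown, and "the series" means these compounds.

In a functional assay on HeLa cells (Homo sapiens) for cytotoxicity, with a stated time of 72 h (a higher number here means a weaker inhibitor, a lower number a stronger inhibitor), compound 1 `Clc1ccc(Cc2nn3cc(-c4ccc(Br)cc4)nc3s2)cc1` gives > 250000 nM, a limit of the assay.
In this assay compound 2 `O=[N+]([O-])c1ccc(-c2cn3nc(Cc4ccc(Cl)cc4)sc3n2)cc1` gives > 250000 nM, a limit of the assay.
In this assay compound 3 `Clc1ccc(Cc2nn3c(Br)c(-c4ccc(Cl)cc4)nc3s2)cc1` gives > 250000 nM, a limit of the assay.

Compound 3 thus stands at the limit of > 250000 nM in this assay, at which 3 of the 3 values shown sit; no number is reported for it. Among the compounds with values here, the one step between measured compounds, a step that the two limits leave unreadable from compound 1 to compound 2, runs between two limits and has no readable size. Compound 4 `COc1ccc(-c2nc3sc(Cc4ccc(Cl)cc4)nn3c2Br)cc1` differs from compound 3 by methoxy in place of chloro on an aromatic carbon. Within the data shown here, no measured step bears on this change, and the series holds no readable step at all, so neither direction nor size can be drawn from it. The expected step of a number no higher from compound 3 to compound 4 (the limit leaves the size open) is therefore set to none beyond the scatter. For compound 4 the estimate is 250000 nM, with a range from 60000 nM to 600000 nM, and a limit remains the likeliest report in this assay.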

Compound 4, half-maximal inhibitory concentration: 66000 nM
For compound 4 the middle estimate is 3.8-fold (0.58 log units) above the measured one; the measured number falls inside the stated range.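

Within the data shown here, the para position of the six-membered aromatic ring responds to substitution: 4-methoxyphenyl in place of 4-chlorophenyl gives an at least 3.7-fold lower number from compound 3 to compound 4 (0.57 log units; beyond the scatter), the first step in this assay with a readable direction. Compound 4 is the only compound shown with a measured number, while the others remain at a limit: the limit of > 250000 nM in this assay, at which 3 of the 4 values shown sit. Since compound 3 has only a limit, the step gives a minimum, not an exact size.

From the compounds shown here alone, the full size of the step remains open. So does whether an amine or an ethoxy group at this position would lower the number further.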